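The compounds below may be only part of what the source reports. "The series", "measured", "known", "first", "only" and "open" are said of these compounds alone.

Of the compounds shown here, three that share one core have been measured in a functional assay on A-375 cells (Homo sapiens) for antiproliferative activity, read by MTT assay, with a stated time of 72 h; on this read-out lower numbers stand for stronger inhibition and higher numbers for weaker inhibition. Compound 1 `O=[N+]([O-])c1ccc(-c2csc(N3N=C(c4ccc(N5CCCCC5)cc4)CC3c3ccc(Cl)cc3)n2)cc1`, which carries a nitro group, reads > 100000 nM, and this is a limit of the assay, not a true number. Compound 3 `Cc1ccc(-c2csc(N3N=C(c4ccc(N5CCCCC5)cc4)CC3c3ccc(Cl)cc3)n2)cc1` reads > 100000 nM, which is also only a limit. For the measured compounds named here, compound 2 `FC(F)(F)c1ccc(-c2csc(N3N=C(c4ccc(N5CCCCC5)cc4)CC3c3ccc(Cl)cc3)n2)cc1` gives 64200 nM, the only true number so far. Compound 1 therefore stands at the limit of > 100000 nM in this assay, at which 2 of the 3 values shown sit.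

The move to compound 4 `CS(=O)(=O)c1ccc(-c2csc(N3N=C(c4ccc(N5CCCCC5)cc4)CC3c3ccc(Cl)cc3)n2)cc1` is methylsulfonyl in place of nitro on an aromatic carbon. Three measured steps change a group at this same place. They are an at least 1.5-fold lower number from compound 1 to compound 2 (0.19 log units; that floor lies within the scatter), an at least 1.5-fold higher number from compound 2 to compound 3 (0.19 log units; that floor lies within the scatter) and a step that the two limits leave unreadable from compound 1 to compound 3. None of them shows a change beyond the scatter, so no clear shift in either direction is expected here. The expected step is an at least 1.1-fold lower number from compound 1 to compound 4 (0.04 log units; that floor lies within the scatter). A result reported only as a limit would fit this expectation. For compound 4 the estimate is 90000 nM, with an expected range of 35000 nM to 200000 nM.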

Compound 4, half-maximal inhibitory concentration: > 100000 nM
Compound 4 ended at the assay's limit; the forecaster's own chance of this, stated with the estimate: 60%; at least 1.1-fold (0.04 log units) between middle value and limit.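

Compound 4 adds a third group at this place, on an aromatic carbon para to a large group, whose reading in this assay is only a limit, and the series now gathers there: the limit of > 100000 nM in this assay, at which 3 of the 4 values shown sit. The steps to compound 4 from compound 1 and from compound 3 cannot be read, with limits at both ends. For the compounds shown here, the one readable step is an at least 1.5-fold higher number from compound 2 to compound 4 (0.19 log units; that floor lies within the scatter); it gives only a floor, so methylsulfonyl and trifluoromethyl cannot yet be told apart here.

From the compounds shown here alone, it remains open whether any other group at this place, such as an amine, a carboxylic acid or a longer chain, would give a true number well clear of the limit. The compounds shown also leave open whether a change elsewhere on the shared core would do more than a change here.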